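The source may report more compounds than this note shows. Statements on the series, on what has been measured and on what is new or still open speak of the compounds shown alone.

Values in a physicochemical assay for solubility, read by spectrophotometry, in phosphate buffer, with a stated time of 18 h, at pH 7.4 (a lower number here means a less soluble compound, a higher number a more soluble compound), for the measured compounds

- compound 1 (`CCc1ccc(-c2nc3c(c(C)nn3-c3ccccc3)c(-c3ccccc3O)c2C#N)cc1`) gives 3100 nM
- compound 2 (`CCc1ccc(-c2nc3c(c(C)nn3-c3ccccc3)c(-c3ccccc3I)c2C#N)cc1`) gives 8500 nM
- compound 3 (`CCc1ccc(-c2nc3c(c(C)nn3-c3ccccc3C)c(-c3ccccc3O)c2C#N)cc1`) gives 9600 nM

Compound 3 and compound 2 sit level within the usual scatter of repeated measurements, and compound 1 stands clearly lower than both. The next compound to consider is compound 4 (`CCc1ccc(-c2nc3c(c(C)nn3-c3ccc(C)cc3)c(-c3ccccc3O)c2C#N)cc1`). It has the same atoms as compound 3, joined differently, with 4-methylphenyl in place of 2-methylphenyl on an aromatic nitrogen.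

Going by the values given here, two measured steps bear on this change. The closer one (a 3.1-fold higher number from compound 1 to compound 3 (0.49 log units; beyond the scatter)) came from adding a methyl in place of hydrogen on this same ring. Among the compounds with values here, compound 4 also carries a methyl on that ring, but elsewhere, and no measurement yet shows whether the gain survives the move. The other step (a 2.7-fold higher number from compound 1 to compound 2 (0.44 log units; beyond the scatter)) is iodo in place of hydroxy, at a different place, so it only shows what size a single change has reached in this small set.

A modest fall from compound 3 back towards compound 1 is therefore expected in this assay, though no change beyond the scatter remains possible. The expected step is a 2.1-fold lower number from compound 3 to compound 4 (0.33 log units; beyond the scatter) in size and direction. Compound 4 is estimated at 4500 nM (range 1800 nM to 11000 nM) as its likely result.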

Compound 4, solubility: 8900 nM
The estimate for compound 4 lay 2.0-fold (0.30 log units) below the measured number; the measured number falls inside the stated range.
By their numbers in this assay, from the lowest: compound 1; then compounds 2, 4 and 3 (each within the scatter of the next).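

Moving the methyl around the ring on the aromatic nitrogen, with 4-methylphenyl in place of 2-methylphenyl, makes no difference that can be told from the scatter in this assay: the two compounds sit level, at a 1.1-fold lower number from compound 3 to compound 4 (0.03 log units; within the scatter). The rise seen earlier when a methyl replaced a hydrogen on this ring is therefore not tied to the 2-methylphenyl arrangement, since the 4-methylphenyl group gives a similar rise, a 2.9-fold higher number from compound 1 to compound 4 (0.46 log units; beyond the scatter), beyond the scatter. Within these compounds, having a methyl on this ring matters more than which of the two tested places it occupies, although nothing shown gives a reason for this result.

A methyl is the only group shown on this ring, so the compounds leave open whether a longer chain, an amine or a carboxylic acid there would give a similar number. They also leave open how a methyl on this ring would combine with the iodo group of compound 2, which carries the iodo on the other aryl ring in place of the hydroxy.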